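The source may hold more compounds than are shown below. What is called first, only, known or untested is meant among the compounds shown, and "the series" means these compounds.

In an assay on SH-SY5Y cells for inhibition of Voltage-dependent N-type calcium channel subunit alpha-1B (Homo sapiens), read by FLIPR and calcium flux, with stated times of 600 s and 300 s, in the presence of a further agent that is not named here (a higher number here means a weaker inhibitor, a lower number a stronger inhibitor), compound 2 `CN(Cc1ccc(OCCCN)cc1)c1nc2ccc(Oc3ccc(F)cc3)cc2s1` gives 98000 nM, the highest of three numbers, though compound 3 `CN(Cc1ccc(OCCCN)cc1)c1nc2ccc(Oc3cccc(C(F)(F)F)c3)cc2s1` with 77000 nM and compound 1 `CN(Cc1ccc(OCCCN)cc1)c1nc2ccc(Oc3ccc(C#N)cc3)cc2s1` with 65000 nM lie within the scatter of it: the steps of a 1.5-fold higher number from compound 1 to compound 2 (0.18 log units; within the scatter) and a 1.3-fold lower number from compound 2 to compound 3 (0.10 log units; within the scatter) both stay inside the usual spread. Compound 4 `NCCCOc1ccc(CNc2nc3ccc(Oc4ccc(F)cc4)cc3s2)cc1` differs from compound 2 by hydrogen in place of methyl on a nitrogen on an aromatic ring. None of the measured steps touches this nitrogen; all three concern the aryl group on the ether oxygen, so there is no shown step that bears on the change, and no step beyond the scatter in this assay is expected, in either direction. Compound 4 is therefore estimated at 98000 nM, within 40000 nM to 240000 nM, a step of no change at the digits printed from compound 2 to compound 4 (within the scatter).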

Compound 4, half-maximal inhibitory concentration: 106000 nM
For compound 4 the middle estimate is 1.1-fold (0.03 log units) below the measured one; measured number inside the range.
By their numbers in this assay, from the lowest: compounds 1, 3, 2 and 4 (each within the scatter of the next).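

In this assay, for the compounds shown here, the earlier steps all concerned the aryl group on the ether oxygen, and the new one is the first at the nitrogen on an aromatic ring: hydrogen in place of methyl gives a 1.1-fold higher number from compound 2 to compound 4 (0.03 log units; within the scatter). This nitrogen, like that aryl group, has therefore shown no step beyond the scatter, though only this one change at it, with 4-fluorophenyl on the oxygen, can be read. No evidence at hand bears on this result.

As far as these compounds go, whether an ethyl or acetyl group on this nitrogen would also stay within the scatter remains open. So does the outcome of replacing the amine at the end of the other chain with a carboxylic acid, or of using a longer chain there.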